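Methoxy to Hydroxy on the Side Chain of a Curcuminoid

The compounds below may be only part of what the source reports. "The series", "measured", "known", "first", "only" and "open" are said of these compounds alone.

The set holds three measured compounds and one that has not yet been tested. Compound 1 `COc1cc(/C=C/C2=CC(=O)CC(c3ccc(O)c(OC)c3)N2CCCO)ccc1O` gives 88000 nM in a functional assay on Caco-2 cells (Homo sapiens) for cytotoxicity, read by MTT assay, with a stated time of 48 h; on this read-out lower numbers stand for stronger inhibition and higher numbers for weaker inhibition. Compound 2 `COCCCN1C(/C=C/c2ccc(O)cc2)=CC(=O)CC1c1ccc(O)cc1` reaches only a limit of the assay, > 100000 nM, and this is recorded as the limit of > 100000 nM in this assay, at which 1 of the 3 values shown sits, rather than as a number. Compound 3 `COCCNC(=C\C(=O)/C=C/c1ccc(O)cc1)/C=C/c1ccc(O)cc1` gives 28000 nM, which is the lowest of the two numbers shown; compound 1 sits at a higher number, and that gap is beyond the usual scatter, while no direct step between the two is set out, so only their two values can be compared.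

The untested compound 4 `O=C(/C=C(/C=C/c1ccc(O)cc1)NCCO)/C=C/c1ccc(O)cc1` differs from compound 3 in one place: hydrogen in place of methyl on an oxygen on a saturated carbon. Read one bond further out, the change is methoxy to hydroxy, or 2-methoxyethyl to 2-hydroxyethyl, on the chain carried by the nitrogen. For the measured compounds named here, no measured pair in this set isolates such a change, so there is no step to lean on. The step is expected to stay within the scatter, with no clear direction, and is estimated at a 1.1-fold higher number from compound 3 to compound 4 (0.03 log units; within the scatter). Compound 4 is therefore expected to give about 30000 nM, with a likely range from 12000 nM to 80000 nM.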

Compound 4, half-maximal inhibitory concentration: 57900 nM
Compound 4: middle estimate off by 1.9-fold (0.29 log units), on the low side; the measured number falls inside the stated range.
By their numbers in this assay, from the lowest: compound 3; then compounds 4 and 1 (each within the scatter of the next). At a limit, above all of these: compound 2.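

In this assay, the change from 2-methoxyethyl to 2-hydroxyethyl on the chain carried by the nitrogen gives a 2.1-fold higher number from compound 3 to compound 4 (0.32 log units; beyond the scatter), so replacing methyl with hydrogen on this oxygen moves the number towards weaker inhibition, although the step is modest. The earlier compounds shown here offered no pair differing in one place, so they could not show whether this part of the chain affects the read-out at all; this pair shows that it does, though only on a single core and through a single change. Nothing measured among these compounds accounts for the step, so the data give its size and direction but not its cause.

The compounds shown leave open whether the same change would give a step of similar size and direction on another core, such as the one carried by compound 1. For the compounds shown here, they also leave open how an amine, a carboxylic acid or a longer chain ending in hydroxy would read at this place, so the single step cannot yet be extended into a trend.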